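The compounds below may be only part of what the source reports. "The series", "measured", "known", "first", "only" and "open" are said of these compounds alone.

Compounds measured so far:
- compound 1, `CC(C)(CCCCF)[C@H](O)/C=C/[C@H]1COC(=O)N1CCSc1nc(C(=O)O)cs1`: 431 nM
- compound 2, `O=C(O)c1csc(SCCN2C(=O)OC[C@@H]2/C=C/[C@@H](O)C2(CCCCF)CCC2)n1`: 1080 nM

In an assay on isolated protein for binding affinity to prostaglandin E2 receptor EP1 subtype (Homo sapiens) (on this read-out higher numbers stand for weaker inhibition and lower numbers for stronger inhibition), compound 1 gives the lower of the two numbers shown, and compound 2 lies above it by a 2.5-fold higher number from compound 1 to compound 2 (0.40 log units; beyond the scatter). That step swaps the open branched chain of compound 1 for a four-membered ring carrying a fluorinated chain.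

Compound 3, `CCOCCC1([C@H](O)/C=C/[C@H]2COC(=O)N2CCSc2nc(C(=O)O)cs2)CCC1`, has not yet been measured. It differs from compound 1 by 1-(2-ethoxyethyl)cyclobutyl in place of 5-fluoro-1,1-dimethylpentyl on a saturated chain carbon bound to a double-bonded chain carbon and an oxygen on a saturated carbon. The change again replaces the open chain with a four-membered ring, now carrying an ether chain instead of a fluorinated one. For the measured compounds named here, the only step that bears on this is the one from compound 1 to compound 2, which was modest and pointed toward weaker binding. As far as these compounds go, a step of similar direction and size is therefore expected here, a 2.3-fold higher number from compound 1 to compound 3 (0.37 log units; beyond the scatter), with the caveat that the ether chain is untested. Compound 3 is estimated at 1000 nM, within a range from 300 nM to 3300 nM.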

Compound 3, inhibition constant: 8420 nM
Compound 3: middle estimate off by 8.4-fold (0.93 log units), on the low side; measured number above the stated range.
By their numbers in this assay, from the lowest: compound 1; then compound 2; then compound 3.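

In this assay this position turns out to be far more sensitive than the first swap suggested: the change to 1-(2-ethoxyethyl)cyclobutyl gives a 20-fold higher number from compound 1 to compound 3 (1.29 log units; beyond the scatter) and counts as large, whereas a 2.5-fold higher number from compound 1 to compound 2 (0.40 log units; beyond the scatter) was modest. With the four-membered ring kept, ethoxy in place of 2-fluoroethyl still gives a 7.8-fold higher number from compound 2 to compound 3 (0.89 log units; beyond the scatter) on its own, so the ring alone does not set the number and what the chain carries matters too. No measurement shown here explains why the ether chain gives the weaker binding.

As far as these compounds go, it remains open whether a plain pentyl chain, made of carbon only, would read closer to compound 2 or to compound 3. From the compounds shown here alone, it is also open how an amine in place of the ethoxy would read on the same four-membered ring.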